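The source may hold more compounds than are shown below. What is called first, only, known or untested is meant among the compounds shown, and "the series" means these compounds.

Working notes on the series. Of the compounds shown here, three so far carry numbers in a functional assay on LOX IMVI cells (Homo sapiens) for inhibition, read by sulforhodamine B assay, with a stated time of 48 h; a higher number here means a weaker inhibitor of growth, a lower number a stronger inhibitor of growth. Compound 1 `N#C/C(=C\N1CCN(C(=O)c2ccco2)C1=S)C(N)=O` gives 2500 nM in this assay, the lowest of the three numbers. Compound 2 `O=CN1CCN(c2ccc(Cl)c(Cl)c2)C1=S` gives 9300 nM in this assay, the number furthest from that of compound 1 and beyond the scatter. Compound 3 `O=CN1CCN(c2cc(Cl)cc(Cl)c2)C1=S` gives 7100 nM in this assay, nearer to compound 1 yet still beyond the scatter. Within the data shown here, compounds 2 and 3 differ from compound 1 at more than one place, so no single step is drawn between them and compound 1; only the values are set side by side.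

Compound 4 `N#C/C(=C\N1CCN(C(=O)c2ccco2)C1=S)C(=O)c1ccccc1` has not yet been measured. Against compound 1 the change is phenyl in place of amino on a carbonyl carbon. Cut one bond further out, the same difference reads carbamoyl to benzoyl. Among the measured compounds shown here, no measured pair isolates this change, so the step has no precedent here and the expectation rests on compound 1 alone. The step expected is a 1.2-fold higher number from compound 1 to compound 4 (0.08 log units; within the scatter), taken as none beyond the scatter, with neither direction favoured. Compound 4 is therefore estimated at 3000 nM in this assay, with a range from 1000 nM to 10000 nM.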

Compound 4, concentration for 50% growth inhibition: 17900 nM
Compound 4: middle estimate off by 6.0-fold (0.78 log units), on the low side, and the stated range ends below it.
By their numbers in this assay, from the lowest: compound 1; then compounds 3, 2 and 4 (each within the scatter of the next, the first and the last beyond it).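

Among these compounds, at the carbonyl carbon whose other neighbour is the double-bonded chain carbon, the group carried is not indifferent: in this assay, phenyl in place of amino gives a 7.2-fold higher number from compound 1 to compound 4 (0.85 log units; beyond the scatter) and this is the only single-place step the series can read so far. The direction is towards a weaker inhibitor of growth, so in this one pair the carbamoyl of compound 1 is preferred over the benzoyl of compound 4, though a single pair sets no trend for the position. Nothing at hand on the properties of these two compounds accounts for the step.

The change removes the amino group with its hydrogen-bond donor and brings in a six-membered aromatic ring of carbon at once, so the compounds shown do not separate the two; a dimethylamino or a methyl group on the same carbonyl carbon would bear on that question. Among the compounds shown here, also open is whether the same step holds when the rest of the core of compound 1 carries other groups, since the series holds only this one pair for the change.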